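Removing a Methoxy Group: Expected Growth Inhibition for Compound 3

The compounds below may be only part of what the source reports. "The series", "measured", "known", "first", "only" and "open" are said of these compounds alone.

Compound 1, `COc1ccc(Cc2nnc(NC(=O)/C(C#N)=C/c3ccccc3OS(=O)(=O)c3ccccc3[N+](=O)[O-])s2)cc1`: 18%
Compound 2, `COc1ccc(Cc2nnc(NC(=O)/C(C#N)=C/c3ccccc3OS(=O)(=O)c3ccc(F)cc3)s2)cc1`: 6%

In an ADME assay on HEK-293T cells (Homo sapiens) for inhibition, read by CCK-8 assay, with a stated time of 48 h, tested at 20 uM (on this read-out lower numbers stand for less inhibition of growth and higher numbers for more inhibition of growth at the one concentration tested), compound 1 gives 18%. In the same assay compound 2 gives 6%. Among the compounds with values here, the one measured step is a number 12 percentage points lower from compound 1 to compound 2 (beyond the scatter), with 4-fluorophenyl in place of 2-nitrophenyl on a sulfonyl sulfur. Within the data shown here, compound 2 therefore stands lowest of the two numbers, with compound 1 the only neighbour, higher by more than the scatter.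

Compound 3, `N#C/C(=C\c1ccccc1OS(=O)(=O)c1ccc(F)cc1)C(=O)Nc1nnc(Cc2ccccc2)s1`, differs from compound 2 in one place: hydrogen in place of methoxy on an aromatic carbon. Read one bond further out, the change is 4-methoxybenzyl to benzyl.

Among the measured compounds shown here, no measured step touches this part of the molecule; the single step concerns the sulfonyl sulfur, a different place. Nothing in the numbers therefore points in either direction for this change, and the expected step is a number 2 percentage points higher from compound 2 to compound 3 (within the scatter), within the scatter. Compound 3 is expected to give 8% in this assay, with a range from 0% to 22%.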

Compound 3, percent growth inhibition at one concentration: 6%
Compound 3: middle estimate off by 2 percentage points, on the high side; the range from low to high includes it.
By their numbers in this assay, from the lowest: compounds 2 and 3 (each within the scatter of the next); then compound 1.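

Read in this assay, the change from 4-methoxybenzyl to benzyl gives no change at the digits printed from compound 2 to compound 3 (within the scatter), so this is the first reading at this position and the methoxy group can be removed with no shift beyond the scatter. The only earlier step concerned the sulfonyl sulfur, where the result was a number 12 percentage points lower from compound 1 to compound 2 (beyond the scatter), so among the compounds shown, the substituent on the sulfonyl sulfur is the one change that moves the number beyond the scatter, while hydrogen in place of methoxy does not. No data shown here bear on the reason for this result.

The compounds shown leave open whether a different group on this aromatic carbon, such as an amine, a carboxylic acid or a longer alkoxy chain, would give a number outside the scatter of compound 2 and compound 3. They also leave open whether hydrogen in place of methoxy would have the same outcome with 2-nitrophenyl on the sulfonyl sulfur, as in compound 1, whose number is the highest of the three.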